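The compounds below may be only part of what the source reports. "The series", "measured", "known", "first", "only" and "open" are said of these compounds alone.

Compound 1 `COC(=O)c1c(Cl)cc(Cl)cc1OC(=O)COc1cc(O)c2c(=O)cc(-c3ccccc3)oc2c1` gives 345000 nM in an ADME assay on cells (T-cell, Mus musculus, strain BALB/c) for cytotoxicity, read by MTT assay, with a stated time of 48 h; a lower number here means that less compound is tolerated, a higher number that more compound is tolerated.
Compound 2 `C=C(CCc1cc(O)c2c(=O)cc(-c3ccccc3)oc2c1)Cc1c(Br)cccc1C(=O)CC` gives 379000 nM in this assay.
Compound 3 `COC(=O)c1cccc(OC)c1OC(=O)COc1cc(O)c2c(=O)cc(-c3ccccc3)oc2c1` gives 196000 nM in this assay.

The three numbers sit close together: compound 3 stands at one end of the spread, yet compound 1 and compound 2 both fall within the usual scatter of it, so the three cannot be told apart with confidence. Compound 4 `COC(=O)c1cccc(Cl)c1OC(=O)COc1cc(O)c2c(=O)cc(-c3ccccc3)oc2c1` is not yet measured. It differs from compound 3 in one place: chloro in place of methoxy on an aromatic carbon. Among the measured compounds shown here, with no step between measured compounds to lean on, no change beyond the scatter is expected in this assay. The estimate for compound 4 is 260000 nM, with a range of 130000 nM to 520000 nM, which amounts to an expected step of a 1.3-fold higher number from compound 3 to compound 4 (0.12 log units; within the scatter).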

Compound 4, half-maximal cytotoxic concentration: 366000 nM
Beside the measured number, compound 4's estimate is 1.4-fold (0.15 log units) below it; low and high end bracket the measured number.
By their numbers in this assay, from the lowest: compounds 3, 1, 4 and 2 (each within the scatter of the next).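

Among the compounds shown here, putting chloro in place of methoxy on this aromatic carbon, ortho to a large group, gives a 1.9-fold higher number from compound 3 to compound 4 (0.27 log units; within the scatter) in this assay, the first direct reading of a single change. At this position, then, the two groups cannot be told apart in this measurement, even though one heavy atom replaces two and a hydrogen-bond acceptor is lost. Nothing available explains this result. Going by these compounds, whether an amine, a carboxylic acid or a longer chain on this carbon would give a clearly different number remains open.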